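This account rests on a few compounds, and the source may have more. Where it says the series, first, only, none or still open, it means among the compounds named here.

Working notes on the series in a functional assay on HT-29 cells (Homo sapiens) for cytotoxicity, read by MTT assay; a higher number here means a weaker inhibitor, a lower number a stronger inhibitor. Compound 1 `C=C1C(=O)[C@]23C[C@@]1(O)CC[C@H]2[C@@]12C=CC(=O)[C@](C)(C(=O)O1)[C@H]2[C@@H]3C(=O)OC` gives 65700 nM. Compound 2 `C=C1C(=O)[C@]23C[C@@]1(F)CC[C@H]2[C@@]12C=CC(=O)[C@](C)(C(=O)O1)[C@H]2[C@@H]3C(=O)OC` gives 72700 nM, and compound 3 `C=C1C(=O)[C@]23C[C@@]1(F)CC[C@H]2[C@@]12C=CC(=O)[C@](C)(C(=O)O1)[C@H]2[C@@H]3C(=O)OCc1ccccc1` gives 59100 nM. Compound 2 stands within the scatter of both other compounds, so the three numbers form a single level and show no order.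

The open case is compound 4 `C=C1C(=O)[C@]23C[C@@]1(OC)CC[C@H]2[C@@]12C=CC(=O)[C@](C)(C(=O)O1)[C@H]2[C@@H]3C(=O)OC`, which shares the core of compound 2 and differs in one group: methoxy in place of fluoro on a saturated ring carbon. Among the compounds with values here, two measured steps bear on it. The closer one is a 1.1-fold higher number from compound 1 to compound 2 (0.04 log units; within the scatter), with fluoro in place of hydroxy on that same ring carbon. The other, a 1.2-fold lower number from compound 2 to compound 3 (0.09 log units; within the scatter), has phenyl in place of hydrogen on a saturated chain carbon bound to an oxygen next to a carbonyl group, so it concerns a different part of the molecule. Both steps stay within the scatter. Methoxy itself has not yet been tested on this carbon, so that gap remains. No step beyond the scatter is expected in this assay, and no direction is favoured. The expected step is a 1.1-fold lower number from compound 2 to compound 4 (0.05 log units; within the scatter). For compound 4 the estimated value is 65000 nM, with an expected range of 35000 nM to 110000 nM.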

Compound 4, half-maximal inhibitory concentration: 80200 nM
Compound 4: the middle estimate sits 1.2-fold (0.09 log units) below what was measured; measured number inside the range.
By their numbers in this assay, from the lowest: compounds 3, 1, 2 and 4 (each within the scatter of the next).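

Working notes on the ring carbon in this assay: this position now carries hydroxy, fluoro and methoxy on the same core and ester, and the steps among them stay within the scatter, with a 1.1-fold higher number from compound 2 to compound 4 (0.04 log units; within the scatter) for methoxy in place of fluoro and a 1.2-fold higher number from compound 1 to compound 4 (0.09 log units; within the scatter) for methyl in place of hydrogen on an oxygen on a saturated carbon. Within the data shown here, the second step adds something the earlier compounds did not show: capping the hydroxy oxygen with methyl gives no step beyond the scatter, and neither does replacing the single heavy atom of fluoro with the two heavy atoms of methoxy, which brings one hydrogen-bond acceptor. No measurement at hand explains why the number holds at this level across these three groups.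

As far as these compounds go, whether a larger group on this ring carbon, such as an amine, a carboxylic acid or a longer chain like butoxy, would move the number beyond the scatter remains open. Also open, from the compounds shown here alone, is whether methoxy on this carbon would stay at the same level when paired with the benzyl ester of compound 3.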